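The compounds below may be only part of what the source reports. "The series", "measured", "known", "first", "only" and "open" are said of these compounds alone.

Measured in a functional assay on ECV-304 cells (Homo sapiens) for cytotoxicity; on this read-out lower numbers stand for stronger inhibition and higher numbers for weaker inhibition:
compound 1 `Cc1ccc(/C=C2\SC(=S)N(NS(=O)(=O)c3ccccc3)C2=O)cc1`: > 50000 nM (a limit)
compound 2 `COc1cccc(/C=C2\SC(=S)N(NS(=O)(=O)c3ccccc3)C2=O)c1`: > 50000 nM (a limit)
compound 3 `O=C1/C(=C/c2ccc([N+](=O)[O-])cc2)SC(=S)N1NS(=O)(=O)c1ccccc1`: > 50000 nM (a limit)

In this assay compound 3 gives > 50000 nM, which is a limit and not a number. The same holds across the series, with the limit of > 50000 nM in this assay, at which 3 of the 3 values shown sit, as the only read-out so far.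

Compound 4 `N#Cc1ccc(/C=C2\SC(=S)N(NS(=O)(=O)c3ccccc3)C2=O)cc1` carries cyano in place of nitro on an aromatic carbon, para to a large group: cyano in place of nitro on an aromatic carbon.

The closest measured change is a step that the two limits leave unreadable from compound 1 to compound 3, which also involves nitro. The other two changes of the aromatic group are a step that the two limits leave unreadable from compound 2 to compound 3 and a step that the two limits leave unreadable from compound 1 to compound 2. None of the three gives a size, so they offer no measured direction for the new change. Within the data shown here, they show only that all three compounds end at the same limit.

In this assay no step beyond the usual scatter is expected, and no direction can be assigned. The estimated change is a step that the limit leaves unreadable from compound 3 to compound 4. For compound 4 the estimated value is 60000 nM, with an expected range of 30000 nM to 120000 nM, and a report as a limit is the likeliest outcome.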

Compound 4, half-maximal inhibitory concentration: > 50000 nM
Compound 4: only a limit was reported (the forecaster's own chance of this, stated with the estimate: 85%); the middle value lies beyond the limit too.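

In this assay compound 4 gives > 50000 nM, which is a limit and not a number. Among these compounds, no step between compound 4 and compounds 1, 2 or 3 can be read, and the series rests on a single limit: the limit of > 50000 nM in this assay, at which 4 of the 4 values shown sit. The compounds shown leave open how far each lies beyond that limit and whether changing the aromatic group shifts the read-out in this assay at all.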